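Ether to Amine on the Side Chain of Compound 2

The compounds below may be only part of what the source reports. "The series", "measured", "known", "first", "only" and "open" are said of these compounds alone.

Compound 1 `COCc1nc(Nc2ccc(C(F)(F)F)cc2)c2ccc(-c3ncccc3C(F)(F)F)cc2n1`: 1.5 nM
Compound 2 `CC(C)OCc1nc(Nc2ccc(C(F)(F)F)cc2)c2ccc(-c3ncccc3C(F)(F)F)cc2n1`: 0.3 nM
Compound 3 `O=C(O)COCc1nc(Nc2ccc(C(F)(F)F)cc2)c2ccc(-c3ncccc3C(F)(F)F)cc2n1`: 81 nM

In a functional assay for antagonist activity at transient receptor potential cation channel subfamily V member 1 (Homo sapiens) (a higher number here means a weaker inhibitor, a lower number a stronger inhibitor), compound 2 stands lowest of the three numbers. Its nearest neighbour is reached by a 5.0-fold lower number from compound 1 to compound 2 (0.70 log units; beyond the scatter), its furthest by a 270-fold higher number from compound 2 to compound 3 (2.43 log units; beyond the scatter). Compound 4 `FC(F)(F)c1ccc(Nc2nc(CNC3CCCCC3)nc3cc(-c4ncccc4C(F)(F)F)ccc23)cc1` differs from compound 2 by cyclohexylamino in place of isopropoxy on a saturated chain carbon bound to an aromatic carbon. Going by the values given here, no measured step swaps the oxygen for a nitrogen here, so the guide is indirect: a 5.0-fold lower number from compound 1 to compound 2 (0.70 log units; beyond the scatter) shows that a larger group on this oxygen gave a modest lower number, while a 54-fold higher number from compound 1 to compound 3 (1.73 log units; beyond the scatter) and a 270-fold higher number from compound 2 to compound 3 (2.43 log units; beyond the scatter) show that a carboxy on this chain gave a large higher number. Neither matches the change in compound 4, and a modest higher number is expected, a 3.3-fold higher number from compound 2 to compound 4 (0.52 log units; beyond the scatter). Compound 4 is estimated at 1 nM, within 0.2 nM to 6 nM.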

Compound 4, half-maximal inhibitory concentration: 6 nM
The estimate for compound 4 lay 6.0-fold (0.78 log units) below the measured number; the measured number falls inside the stated range.
By their numbers in this assay, from the lowest: compound 2; then compound 1; then compound 4; then compound 3.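

A nitrogen at this place, carried as cyclohexylamino, keeps the number well clear of the carboxy-bearing side chain (a 14-fold lower number from compound 3 to compound 4 (1.13 log units; beyond the scatter)), but it loses ground against both ethers, modestly against methoxy (a 4.0-fold higher number from compound 1 to compound 4 (0.60 log units; beyond the scatter)) and largely against isopropoxy (a 20-fold higher number from compound 2 to compound 4 (1.30 log units; beyond the scatter)). A larger group at this place therefore does not by itself give a lower number, as the step from methoxy to isopropoxy alone might have suggested.

On these data alone, whether the nitrogen or the ring sets this step stays open, and an isopropylamino or cyclohexyloxy group here would separate the two. No measurement at hand accounts for the step.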